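The source may report more compounds than this note shows. Statements on the series, on what has been measured and on what is new or still open speak of the compounds shown alone.

Among the measured compounds shown here, in an ADME assay on the whole organism (Rattus norvegicus, strain Wistar Han) for pharmacokinetics, read by LC-MS, with a stated time of 7 h, at a dose of 1 mg/kg by the intravenous route (a higher number here means that more of the compound sits outside the plasma, a lower number that more of the compound stays in the plasma), compound 1 `CNC(=O)c1cc(C(=O)N[C@H]2[C@@H]3COC[C@@H]32)cc2c1OC[C@@]2(C)c1ccccc1` gives 1.6 L/kg and stands highest of the two numbers so far, while compound 2 `CNC(=O)c1cc(C(=O)NC2CC2)cc2c1OC[C@H]2c1ccccc1` gives 0.6 L/kg and the gap between them lies beyond the scatter. Compound 3 `CNC(=O)c1cc(C(=O)N[C@H]2[C@@H]3C[C@@H](O)C[C@@H]32)cc2c1OC[C@@]2(C)c1ccccc1` has not yet been measured. It differs from compound 1 on an amide-type nitrogen, where the change is a group of 7 heavy atoms (6 carbon, 1 oxygen; one three-membered non-aromatic ring of carbon only, one five-membered non-aromatic ring of carbon only) in place of a group of 6 heavy atoms (5 carbon, 1 oxygen; one three-membered non-aromatic ring of carbon only, one five-membered non-aromatic ring with 1 hetero atom), on an amide-type nitrogen and the shared core stays the same. For the measured compounds named here, no measured step covers this change. The expected 1.2-fold lower number from compound 1 to compound 3 (0.09 log units; within the scatter) is small, slightly downward and within the scatter of this assay for this pair. The estimate for compound 3 is 1.3 L/kg with 0.7 L/kg to 2.4 L/kg as the expected span.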

Compound 3, volume of distribution at steady state: 2.3 L/kg
Beside the measured number, compound 3's estimate is 1.8-fold (0.25 log units) below it; measured number inside the range.
By their numbers in this assay, from the lowest: compound 2; then compounds 1 and 3 (each within the scatter of the next).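

On an amide-type nitrogen, the group with a five-membered non-aromatic ring of carbon only and 1 hydrogen-bond donor replaces the group with a five-membered non-aromatic ring with 1 hetero atom, and this assay shows a 1.4-fold higher number from compound 1 to compound 3 (0.16 log units; within the scatter). Among the compounds shown here, this is the first single-place step at this position, and it shows that this exchange leaves the read-out within the scatter. Nothing available bears on the reason for this result. The compounds shown leave open whether a group carrying an amine or a carboxylic acid on this nitrogen, or a longer chain there, would give a step beyond the scatter.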